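Methoxy for chloro on the shared core: compound 4 outlook

A few compounds are considered here, and "the series" means these few. Any claim that something is new, unique, unknown or untested is made for them only; others in the source may bear on it.

Measured values, all in a functional assay on cells (Cancer cell lines, Homo sapiens) for cytotoxicity, with a stated time of 48 h; on this read-out higher numbers stand for weaker inhibition of growth and lower numbers for stronger inhibition of growth:
compound 1 `COc1cc2c(/C=C3/C(=O)Nc4ccc(O)cc43)c(Cl)n(Cc3cc(OC)c(OC)c(OC)c3)c2cc1C` — 34700 nM
compound 2 `COc1cc2c(/C=C3/C(=O)Nc4ccc(Cl)cc43)c(Cl)n(Cc3cc(OC)c(OC)c(OC)c3)c2cc1C` — 5500 nM
compound 3 `COc1cc2c(/C=C3/C(=O)Nc4cccc(Cl)c43)c(Cl)n(Cc3cc(OC)c(OC)c(OC)c3)c2cc1C` — 15100 nM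

Compound 2 holds the lowest number of the three. The two steps that set it apart are a 2.7-fold higher number from compound 2 to compound 3 (0.44 log units; beyond the scatter) and a 6.3-fold lower number from compound 1 to compound 2 (0.80 log units; beyond the scatter), both beyond the scatter but modest in size.

Compound 4 `COc1ccc2c(c1)/C(=C\c1c(Cl)n(Cc3cc(OC)c(OC)c(OC)c3)c3cc(C)c(OC)cc13)C(=O)N2` is not yet measured. It differs from compound 2 by methoxy in place of chloro on an aromatic carbon.

Going by the values given here, only one measured step touches this place directly: a 6.3-fold lower number from compound 1 to compound 2 (0.80 log units; beyond the scatter), where chloro replaced hydroxy on the same aromatic carbon and the number fell. The step of a 2.7-fold higher number from compound 2 to compound 3 (0.44 log units; beyond the scatter) moves the chloro to another carbon and is less informative here. Among the compounds with values here, no measured compound carries methoxy at this position, so the size of the coming step is read by analogy: methoxy, like hydroxy, puts an oxygen on that carbon, and the number is expected to rise from compound 2, probably by less than the full return to compound 1 because the hydroxy of compound 1 gave 34700 nM while methoxy lacks its donor.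

Compound 4 is therefore estimated at 15000 nM, with a range of 6000 nM to 40000 nM. That estimate corresponds to an expected step of a 2.7-fold higher number from compound 2 to compound 4 (0.44 log units; beyond the scatter).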

Compound 4, concentration for total growth inhibition: 57500 nM
Estimate against measurement, compound 4: 3.8-fold (0.58 log units) below; the whole stated range lies below it.
By their numbers in this assay, from the lowest: compound 2; then compound 3; then compounds 1 and 4 (each within the scatter of the next).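

In this assay, going by these compounds alone, the change from chloro to methoxy at this aromatic carbon gives a 10-fold higher number from compound 2 to compound 4 (1.02 log units; beyond the scatter), the largest step so far and the first one rated large. Methyl in place of hydrogen on the oxygen gives a 1.7-fold higher number from compound 1 to compound 4 (0.22 log units; within the scatter), so on this read-out the methoxy and hydroxy compounds cannot be told apart, and the oxygen-bearing groups at this carbon stand together, with compound 2 and its chloro well apart from both. The gain seen earlier on going from hydroxy to chloro therefore does not depend on the hydrogen of the hydroxy group, and no measurement at hand addresses what lies behind the gap between chloro and the two oxygen-bearing groups.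

The compounds shown leave open whether the low number is particular to chloro or is shared at this carbon by groups such as fluoro, bromo, methyl or an amine. Also open, on these data alone, are whether a longer ether such as ethoxy stays with methoxy, and whether methoxy on the carbon that carries chloro in compound 3 would follow the same course.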